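Methyl for Ethoxy on the Aryl Ketone of Compound 1

This account rests on a few compounds, and the source may have more. Where it says the series, first, only, none or still open, it means among the compounds named here.

Within the data shown here, compound 1 `CCOc1ccc(C(=O)/C=C/c2c(/C=C/c3ccc(OC)cc3)cc(OC)cc2OC)cc1` gives 6.4 ug/mL in a functional assay on B16-F10 cells (Mus musculus) for antiproliferative activity, read by MTT assay, with a stated time of 48 h (a higher number here means a weaker inhibitor, a lower number a stronger inhibitor), the highest of the three numbers measured so far. Compound 3 `COc1ccc(/C=C/c2cc(OC)cc(OC)c2/C=C/C(=O)c2ccccc2C)cc1` sits at 6.1 ug/mL, and compound 2 `COc1ccc(/C=C/c2cc(OC)cc(OC)c2/C=C/C(=O)c2ccc(N)cc2)cc1` at 2.8 ug/mL. The step of a 1.0-fold lower number from compound 1 to compound 3 (0.02 log units; within the scatter) stays within the scatter, whereas a 2.3-fold lower number from compound 1 to compound 2 (0.36 log units; beyond the scatter) and a 2.2-fold higher number from compound 2 to compound 3 (0.34 log units; beyond the scatter) are modest moves. Compound 4 `COc1ccc(/C=C/c2cc(OC)cc(OC)c2/C=C/C(=O)c2ccc(C)cc2)cc1` differs from compound 1 in one place: methyl in place of ethoxy on an aromatic carbon. Among the measured compounds shown here, the closest precedent is the change from compound 1 to compound 3, which also exchanged an ethoxy-bearing ring for a methyl-bearing one without leaving the scatter; only the amino of compound 2 moved the number. Compound 4 is therefore expected to give 5.5 ug/mL (range 3 ug/mL to 10 ug/mL), an expected step of a 1.2-fold lower number from compound 1 to compound 4 (0.07 log units; within the scatter) that stays within the scatter.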

Compound 4, half-maximal inhibitory concentration: 5.3 ug/mL
The estimate for compound 4 lay 1.0-fold (0.02 log units) above the measured number; the range from low to high includes it.
By their numbers in this assay, from the lowest: compounds 2, 4, 3 and 1 (each within the scatter of the next, the first and the last beyond it).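

In this assay the change from 4-ethoxyphenyl to 4-methylphenyl leaves the number within the scatter, with a 1.2-fold lower number from compound 1 to compound 4 (0.08 log units; within the scatter) as the step, and moving the methyl gives a 1.2-fold lower number from compound 3 to compound 4 (0.06 log units; within the scatter) and also stays within it. The amino group loses its clear edge here, since a 1.9-fold higher number from compound 2 to compound 4 (0.28 log units; within the scatter) stays within the scatter while its steps to the ethoxy and 2-methylphenyl compounds do not. Nothing available explains these numbers. On these data alone, whether a hydroxyl, a dimethylamino group or a longer chain such as propoxy at this place would separate from methyl or amino remains open.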